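Swapping the pyrrole of compound 2 for dihydroxyphenyl

This account rests on a few compounds, and the source may have more. Where it says the series, first, only, none or still open, it means among the compounds named here.

Results in a functional assay on P388 cells (Mus musculus) for cytotoxicity; a higher number here means a weaker inhibitor, a lower number a stronger inhibitor:
Compound 1 `COc1cccc(Cc2cn(C3CC3)c3c(F)c(-c4cc(C)nc(C)c4)c(F)cc3c2=O)c1`: 20000 nM
Compound 2 `Cc1cc(-c2c(F)cc3c(=O)c(Cc4ccc[nH]4)cn(C4CC4)c3c2F)cc(C)n1`: 930 nM

Of these two compounds, compound 2 has the lower number, at 930 nM. The next compound, compound 3 `Cc1cc(-c2c(F)cc3c(=O)c(Cc4cccc(O)c4O)cn(C4CC4)c3c2F)cc(C)n1`, keeps the shared core and differs from compound 2 at one place: 2,3-dihydroxyphenyl in place of 1H-pyrrol-2-yl on a saturated chain carbon bound to an aromatic carbon. In words, 2,3-dihydroxyphenyl stands in place of 1H-pyrrol-2-yl on a saturated chain carbon bound to an aromatic carbon.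

For the measured compounds named here, only one measured step bears on this place: a 22-fold lower number from compound 1 to compound 2 (1.33 log units; beyond the scatter). It is large and shows that a change here can move the number widely in this assay. Compound 1 also carries a six-membered aromatic ring of carbon only at this place, and it stands at 20000 nM. Its 3-methoxyphenyl group is not the group in question, however, so only a partial move in that direction is expected. The expected change is a moderate rise: a 2.7-fold higher number from compound 2 to compound 3 (0.43 log units; beyond the scatter). The estimate for compound 3 is 2500 nM, with an expected range of 400 nM to 12000 nM.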

Compound 3, half-maximal inhibitory concentration: 880 nM
Compound 3: the middle estimate sits 2.8-fold (0.45 log units) above what was measured; measured number inside the range.
By their numbers in this assay, from the lowest: compounds 3 and 2 (each within the scatter of the next); then compound 1.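

In this assay, the step from the 1H-pyrrol-2-yl group to the 2,3-dihydroxyphenyl group is a 1.1-fold lower number from compound 2 to compound 3 (0.02 log units; within the scatter), so a six-membered aromatic ring of carbon only on this saturated chain carbon does not by itself go with the high number of compound 1. The step between the two groups that both carry such a ring is a 23-fold lower number from compound 1 to compound 3 (1.36 log units; beyond the scatter). A large difference at this place is thus seen between two groups that differ in what the ring bears, and not only with a change of ring type as the earlier step alone allowed. Nothing available explains why the 3-methoxyphenyl group stands apart from the other two groups at this place.

The compounds shown do not tell whether both hydroxyl groups of the 2,3-dihydroxyphenyl group are needed to keep the number near that of compound 2, a question that a 3-hydroxyphenyl or 2-hydroxyphenyl group would address. As far as these compounds go, it also stays open how other groups at this place, such as a 3-aminophenyl group or a furan-2-yl ring, would stand in this assay.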